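Removing a methyl from the aryl ring of a thiazolylidene hydrazide

The source may report more compounds than this note shows. Statements on the series, on what has been measured and on what is new or still open speak of the compounds shown alone.

This piece concerns a small set of hydrazide compounds built on a shared core, tested in a functional assay on C6 cells (Rattus norvegicus) for cytotoxicity, read by MTT assay, with a stated time of 24 h; on this read-out lower numbers stand for stronger inhibition and higher numbers for weaker inhibition. Compound 1, with the structure `Cc1ccc(-c2cs/c(=N/NC(=O)CSc3nnnn3-c3ccccc3)n2-c2ccccc2)cc1`, gives 14.7 ug/mL in this assay. Compound 3, with the structure `O=C(CSc1ncccn1)N/N=c1/scc(-c2ccc(F)cc2)n1-c1ccccc1`, gives 110 ug/mL. Compound 2, with the structure `Cc1nnc(SCC(=O)N/N=c2/scc(-c3ccc(C#N)cc3)n2-c2ccccc2)s1`, has the entry "not determined" (no result reported), so no number is available for it. Among the two numbers shown, compound 1 stands at the lowest, with compound 3 sitting at a higher number; the gap between compound 1 and compound 3 lies beyond the usual scatter of repeated measurements.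

The next compound, compound 4, has the structure `O=C(CSc1nnnn1-c1ccccc1)N/N=c1/scc(-c2ccccc2)n1-c1ccccc1`. It differs from compound 1 in a single place on the six-membered aromatic ring of carbon only that sits para to a large group: hydrogen in place of methyl on an aromatic carbon. Cut one bond further out, the same difference reads 4-methylphenyl to phenyl.

Within the data shown here, no pair of measured compounds shows a comparable change, so there is no measured step to lean on. The expected step from compound 1 to compound 4 in this assay is a 1.5-fold higher number from compound 1 to compound 4 (0.18 log units; within the scatter), a small shift that may not exceed the scatter. Compound 4 is therefore estimated to give about 22 ug/mL in this assay, with a likely range from 9 ug/mL to 55 ug/mL.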

Compound 4, half-maximal inhibitory concentration: 8.3 ug/mL
For compound 4 the middle estimate is 2.7-fold (0.42 log units) above the measured one, outside the stated range (below it).
By their numbers in this assay, from the lowest: compounds 4 and 1 (each within the scatter of the next); then compound 3.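

Among these compounds, this is the first comparison in the set between two compounds that differ in only one place, so it isolates the methyl on the six-membered aromatic ring, para to a large group. In this assay the change from 4-methylphenyl to phenyl gives a 1.8-fold lower number from compound 1 to compound 4 (0.25 log units; within the scatter) and so the two compounds cannot be told apart on this read-out, which means that the methyl makes no detectable difference to the result at this position in this compound pair. No measured evidence is available to explain this outcome, and a single pair gives no basis for a general rule about this position.

As far as these compounds go, only hydrogen and methyl can be compared directly here, so the effect of a larger or quite different group at this ring carbon, such as methoxy or an amine, remains open. Compound 2 and compound 3 carry other groups on this ring but also differ in the ring attached through sulfur, so they cannot show whether removing or replacing the substituent here would have a similar effect with a different ring in that part of the molecule.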